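A few compounds are considered here, and "the series" means these few. Any claim that something is new, unique, unknown or untested is made for them only; others in the source may bear on it.

Compound 3 `Cc1ccc(Oc2c(/C=N\OCc3c(Cl)c(-c4ccc(Cl)cc4)nn3C)c(C)nn2C)cc1` stands second highest of the three numbers measured in a functional assay on SMMC-7721 cells (Homo sapiens) for antiproliferative activity, read by MTT assay, with a stated time of 72 h (on this read-out higher numbers stand for weaker inhibition and lower numbers for stronger inhibition), where compound 3 gives 5840 nM. For the measured compounds named here, its nearest neighbour is compound 2 `Cc1nn(C)c(Oc2ccc(Cl)cc2)c1/C=N\OCc1c(Cl)c(-c2ccc(Cl)cc2)nn1C`, for which compound 2 gives 6820 nM; the only single-place step measured here is a 1.2-fold lower number from compound 2 to compound 3 (0.07 log units; within the scatter). The furthest is compound 1 `COc1ccc(Oc2c(/C=N\OCc3c(Cl)c(-c4ccc(F)cc4)nn3C)c(C)nn2C)cc1`, for which compound 1 gives 2050 nM, a number beyond the scatter from that of compound 3.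

Compound 4 `COc1ccc(Oc2c(/C=N\OCc3c(Cl)c(-c4ccc(Cl)cc4)nn3C)c(C)nn2C)cc1` arises from compound 3 by one change: methoxy in place of methyl on an aromatic carbon. Going by the values given here, no measured step bears directly on a methoxy in place of a methyl on this ring. Among the compounds with values here, what the numbers do show is that compound 1, which carries the same 4-methoxyphenoxy group as compound 4 but differs from it elsewhere, gives the lowest number of the three, while the single measured step, from compound 2 to compound 3, stayed within the scatter. On that basis a modest move toward the number of compound 1 is expected, with no assurance that it will exceed the scatter.

The estimate for compound 4 in this assay is 3500 nM, with a range from 1500 nM to 8000 nM, which is expected to mean a step of a 1.7-fold lower number from compound 3 to compound 4 (0.22 log units; within the scatter).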

Compound 4, half-maximal inhibitory concentration: 760 nM
The estimate for compound 4 lay 4.6-fold (0.66 log units) above the measured number, and the stated range ends above it.
By their numbers in this assay, from the lowest: compound 4; then compound 1; then compounds 3 and 2 (each within the scatter of the next).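

In this assay the change from 4-methylphenoxy to 4-methoxyphenoxy gives a 7.7-fold lower number from compound 3 to compound 4 (0.89 log units; beyond the scatter) and so shows that this position can move the number well beyond the scatter, which the earlier step of a 1.2-fold lower number from compound 2 to compound 3 (0.07 log units; within the scatter) between chloro and methyl on the same carbon did not show. Methoxy in place of chloro at this place gives a 9.0-fold lower number from compound 2 to compound 4 (0.95 log units; beyond the scatter) of similar size, so among the three groups seen on this carbon, para to a large group, methoxy alone stands apart from the other two. With methoxy in place, chloro in place of fluoro on the other aromatic ring gives a 2.7-fold lower number from compound 1 to compound 4 (0.43 log units; beyond the scatter). For the compounds shown here, this is the first single-place step measured on that ring.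

No measurement at hand accounts for any of these steps. From the compounds shown here alone, it remains open whether an ethoxy group, a hydroxyl group or an amine on this carbon would match methoxy, and whether the methoxy step would be as large with fluoro in place of chloro on the other ring.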